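This account rests on a few compounds, and the source may have more. Where it says the series, first, only, none or still open, it means among the compounds named here.

Series notes, step from compound 1 to compound 3.

Compound 1 `Nc1cc(N)c2nc(-c3ccccc3)c(Oc3ccc(Cl)c(Cl)c3)nc2c1` carries a 3,4-dichlorophenoxy group on the shared core. In a functional assay on HOP-62 cells (Homo sapiens) for inhibition, read by sulforhodamine B assay, with a stated time of 48 h (a higher number here means that more compound is tolerated, a lower number that less compound is tolerated), compound 1 gives 85100 nM. Within the data shown here, that is the only plain number obtained so far in this assay. Compound 2 `COc1cc(CNc2nc3cc(N)cc(N)c3nc2-c2ccccc2)cc(OC)c1OC` is reported in this assay only as a limit, < 50200 nM, the limit described by the limit of < 50200 nM in this assay, at which 1 of the 2 values shown sits. Among the measured compounds shown here, no two measured compounds differ in a single place, so there is no measured step size to lean on within this set.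

Compound 3 `Nc1cc(N)c2nc(-c3ccccc3)c(Sc3ccc(Cl)c(Cl)c3)nc2c1` is the next entry. Relative to compound 1 the change is (3,4-dichlorophenyl)sulfanyl in place of 3,4-dichlorophenoxy on an aromatic carbon. The 3,4-dichlorophenoxy group leaves and (3,4-dichlorophenyl)sulfanyl enters on an aromatic carbon of the shared core, the rest of the molecule untouched. For the measured compounds named here, with no measured step available, the expected step from compound 1 to compound 3 in this assay is a 1.2-fold lower number from compound 1 to compound 3 (0.08 log units; within the scatter), which is expected to stay within the usual scatter, with only a slight lean toward less compound being tolerated. For compound 3 the estimate in this assay is 70000 nM, expected to fall between 25000 nM and 200000 nM.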

Compound 3, concentration lethal to 50% of the cells: < 100000 nM
Compound 3 was reported as a limit; the forecaster's own chance of this, stated with the estimate: 20%; the middle value is on the limit's open side.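

Compound 3 is reported only as a limit in this assay, and the step from compound 1 to compound 3 cannot be read: the limit of < 100000 nM in this assay, at which 1 of the 3 values shown sits.

The compounds shown leave open whether (3,4-dichlorophenyl)sulfanyl in place of 3,4-dichlorophenoxy on an aromatic carbon of the shared core changes the read-out of this assay, and by how much.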